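Benzothiazolyl in place of phenyl: outlook for compound 3

The source may report more compounds than this note shows. Statements on the series, on what has been measured and on what is new or still open speak of the compounds shown alone.

Compound 1 `c1ccc(-c2ccc(Cn3cncc3CNc3cccc(-c4ccccc4)c3)cc2)cc1` gives 10000 nM in a toxicity assay on NIH3T3 cells (Mus musculus) for cytotoxicity, read by resazurin assay; a lower number here means that less compound is needed, a higher number that more compound is needed for the effect. Compound 2 `c1ccc(-c2ccc(Cn3cncc3CNc3ccc(-c4ccccc4)c(-c4ccccc4)c3)cc2)cc1` reaches only a limit of this assay, > 10000 nM, not a number. Among the measured compounds shown here, the single measured step of a number no lower from compound 1 to compound 2 (the limit leaves the size open) ends at the limit of > 10000 nM in this assay, at which 1 of the 2 values shown sits. Compound 3 `c1ccc(-c2ccc(Cn3cncc3CNc3ccc(-c4nc5ccccc5s4)c(-c4ccccc4)c3)cc2)cc1` differs from compound 2 by 1,3-benzothiazol-2-yl in place of phenyl on an aromatic carbon. No measured step covers this exchange, and the one shown leaves its size open, so no change beyond the scatter is expected in this assay. The estimated step is a step that the limit leaves unreadable from compound 2 to compound 3. Compound 3 is expected to give about 12000 nM, between 5000 nM and 30000 nM, probably again reported only as a limit.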

Compound 3, half-maximal effective concentration: > 1000 nM
Compound 3: a limit, no number; the forecaster's own chance of this, stated with the estimate: 70%; the middle value does not contradict the limit.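

In this assay, among the compounds shown here, no step to compound 3 can be read from compound 1 or compound 2. Compound 3 gives only a limit, > 1000 nM. The compounds shown leave open what size of change, if any, 1,3-benzothiazol-2-yl in place of phenyl brings.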